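This account rests on a few compounds, and the source may have more. Where it says the series, first, only, none or still open, it means among the compounds named here.

Working notes on the series, from compound 1 `CC(=O)N[C@@H]1CCC[C@H](C(=O)Nc2cc(-c3cnc4ccccn34)c(Cl)cn2)C1` and compound 2 `CC(=O)N[C@@H]1CCC[C@H](C(=O)Nc2cc(-c3cnn4c3COCC4)c(Cl)cn2)C1`. In a physicochemical assay for solubility, in phosphate buffer, at pH 7.4 (a lower number here means a less soluble compound, a higher number a more soluble compound), compound 1 gives 120000 nM. Compound 2 gives 220000 nM, which stands level with compound 1 within the scatter, so the two numbers shown do not separate these compounds.

Among the compounds with values here, compound 3 `CC(=O)N[C@@H]1CCC[C@H](C(=O)Nc2cc(-c3cnc4n3CC(C)(C)C4)c(Cl)cn2)C1` has no measurement yet. Its difference from compound 2 is a group of 10 heavy atoms (8 carbon, 2 nitrogen; one five-membered non-aromatic ring with 1 hetero atom, one five-membered aromatic ring with 2 hetero atoms) in place of a group of 9 heavy atoms (6 carbon, 2 nitrogen, 1 oxygen; one five-membered aromatic ring with 2 hetero atoms, one six-membered non-aromatic ring with 2 hetero atoms), on an aromatic carbon, ortho to a chloro group and opposite the ring nitrogen. All three groups at this carbon carry a five-membered aromatic ring with 2 hetero atoms. Within the data shown here, only one measured step bears on the change: a 1.8-fold higher number from compound 1 to compound 2 (0.26 log units; within the scatter), a swap of one such group for another at the same carbon, and it stayed within the scatter. A single step is thin evidence and shows no pattern, but it gives no reason to expect a large shift in this assay. The expected change is a 1.4-fold lower number from compound 2 to compound 3 (0.14 log units; within the scatter), so no step beyond the scatter is expected in either direction. Compound 3 is estimated at 160000 nM, with an expected range of 70000 nM to 330000 nM.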

Compound 3, solubility: 280000 nM
Estimate against measurement, compound 3: 1.8-fold (0.24 log units) below; measured number inside the range.
By their numbers in this assay, from the lowest: compounds 1, 2 and 3 (each within the scatter of the next, the first and the last beyond it).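

At the aromatic carbon opposite the ring nitrogen, replacing the group with the six-membered non-aromatic ring by the one with the five-membered non-aromatic ring gives a 1.3-fold higher number from compound 2 to compound 3 (0.10 log units; within the scatter) in this assay, so the two groups are not separated even though only the first contains oxygen. Within the data shown here, the first step beyond the scatter at this carbon is the modest 2.3-fold higher number from compound 1 to compound 3 (0.37 log units; beyond the scatter), which replaces the group with the six-membered aromatic ring by the same group with the five-membered non-aromatic ring, while compound 2 remains within the scatter of both other compounds, so the three numbers form a small spread with only its two ends separated. No measurement shown explains these differences.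

From the compounds shown here alone, all three groups at this carbon carry a five-membered aromatic ring with 2 hetero atoms, so it remains open whether a group without that ring, such as a simple phenyl ring, would stay within this spread. Also open, going by these compounds, is how far the number would move with an amine or a carboxylic acid on the group at this carbon, or with a methoxy group in place of the chloro group.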